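Cytotoxicity in TZM cells: from hydroxy to nitro

The compounds below may be only part of what the source reports. "The series", "measured", "known", "first", "only" and "open" are said of these compounds alone.

Measured compounds:
compound 1 `COc1ccc(C2=Cc3ccc(F)cc3C(CC(C)=O)N2c2ccc([N+](=O)[O-])cc2)cc1` 11200 nM
compound 2 `COc1ccc(C2=Cc3ccc(F)cc3C(CC(=O)CO)N2c2ccc(C#N)cc2)cc1` 39700 nM
compound 3 `COc1ccc(C2=Cc3ccc(F)cc3C(CC(=O)CO)N2c2ccc(O)cc2)cc1` 47700 nM

In an ADME assay on TZM cells (Homo sapiens) for cytotoxicity, read by CellTiter-Glo, with a stated time of 48 h (a higher number here means that more compound is tolerated, a lower number that less compound is tolerated), compound 3 gives the highest of the three numbers; compound 2 is within the scatter of it, and compound 1 lies well below it. Among the compounds with values here, the only single-point step measured, a 1.2-fold higher number from compound 2 to compound 3 (0.08 log units; within the scatter), is within the scatter. Compound 4 `COc1ccc(C2=Cc3ccc(F)cc3C(CC(=O)CO)N2c2ccc([N+](=O)[O-])cc2)cc1` carries nitro in place of hydroxy on an aromatic carbon. Within the data shown here, no measured step covers this change. Compound 1, which also bears a nitro group, gives a lower number than compound 3, though the two differ elsewhere as well. Compound 4 is therefore expected to show a lower number than compound 3, the step being a 2.7-fold lower number from compound 3 to compound 4 (0.42 log units; beyond the scatter). The estimate for compound 4 is 18000 nM, with a range from 7000 nM to 45000 nM.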

Compound 4, half-maximal cytotoxic concentration: 46400 nM
For compound 4 the middle estimate is 2.6-fold (0.41 log units) below the measured one; the measured number lies above the stated range.
By their numbers in this assay, from the lowest: compound 1; then compounds 2, 4 and 3 (each within the scatter of the next).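

In this assay, hydroxy, nitrile and nitro at this place on the aromatic ring all give numbers within the scatter of one another (a 1.0-fold lower number from compound 3 to compound 4 (0.01 log units; within the scatter); a 1.2-fold higher number from compound 2 to compound 4 (0.07 log units; within the scatter)). Compound 1 and compound 4 both carry the nitro group, yet they stand apart beyond the scatter where hydroxy replaces hydrogen on the chain (a 4.1-fold higher number from compound 1 to compound 4 (0.62 log units; beyond the scatter)), so the low number of compound 1 does not follow from nitro alone. Nothing at hand explains these numbers. As far as these compounds go, whether an amine or a carboxylic acid at this ring place would fit the same picture stays open. So does whether the chain change gives a similar step with hydroxy or nitrile on the ring.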